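From Methyl to Benzyl on Selenium: an Expected Shift

This account rests on a few compounds, and the source may have more. Where it says the series, first, only, none or still open, it means among the compounds named here.

Three measured compounds share a central unit in which a selenium atom is flanked by two acyl groups. Compound 1 `C[Se]/C(=N\C(=O)c1cccs1)NC(=O)c1cccs1` is the reference point. In a functional assay on K562 cells (Homo sapiens) for cytotoxicity, read by MTT assay, with a stated time of 72 h (a lower number here means a stronger inhibitor of growth, a higher number a weaker inhibitor of growth), compound 1 gives 6070 nM, the lowest of the three numbers. Compound 2 `C[Se]/C(=N\C(=O)c1ccco1)NC(=O)c1ccco1` gives 8780 nM in this assay, which lies within the usual scatter of compound 1, so the two cannot be separated. Compound 3 `O=C(/N=C(/NC(=O)c1cnc2ccccc2c1)[Se]Cc1ccccc1)c1cnc2ccccc2c1` gives 29300 nM in this assay, a gap from compound 1 that lies beyond the scatter; compound 3 differs from compound 1 in more than one place, so this gap cannot be tied to a single change.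

Compound 4 `O=C(/N=C(/NC(=O)c1cccs1)[Se]Cc1ccccc1)c1cccs1` has not yet been measured. It differs from compound 1 in one place: phenyl in place of hydrogen on a saturated chain carbon bound to a selenium atom. Among the measured compounds shown here, no measured pair shows this change on its own. Compound 3 also carries a benzyl group on selenium, yet its acyl groups differ as well, so it only hints at direction. The step from compound 1 to compound 4 is expected to be modest and toward a higher number, with a 1.6-fold higher number from compound 1 to compound 4 (0.22 log units; within the scatter) possibly staying within the scatter. Compound 4 is therefore expected to give about 10000 nM in this assay, with a likely range from 4000 nM to 30000 nM.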

Compound 4, concentration for 50% growth inhibition: 29500 nM
For compound 4 the middle estimate is 3.0-fold (0.47 log units) below the measured one; the range from low to high includes it.
By their numbers in this assay, from the lowest: compounds 1 and 2 (each within the scatter of the next); then compounds 3 and 4 (each within the scatter of the next).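

Among the compounds shown here, the change from methyl to benzyl on selenium, with nothing else altered, gives in this assay a 4.9-fold higher number from compound 1 to compound 4 (0.69 log units; beyond the scatter) and is the first measured case of this change on its own. This pair shows that the position on selenium is not indifferent to what it carries: adding a phenyl in place of hydrogen on the saturated chain carbon bound to selenium is enough by itself to make the compound a clearly weaker inhibitor of growth. The data give the direction and size of this step, but nothing measured here offers an explanation for it.

The compounds shown leave open how the number moves with other groups on selenium, such as an ethyl group, a longer chain, or a chain ending in an amine or a carboxylic acid. They also leave open whether the change from methyl to benzyl gives a step of similar size when the shared core carries the acyl groups of compound 2.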